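Hydroxyamino versus methoxyamino thiosemicarbazones: MT4 cytotoxicity notes

The compounds below may be only part of what the source reports. "The series", "measured", "known", "first", "only" and "open" are said of these compounds alone.

Measured so far:
compound 1 `CCN(CC)CN1C(=O)/C(=N\NC(=S)NO)c2cc(Cl)ccc21` — 562000 nM
compound 2 `CONC(=S)N/N=C1\C(=O)N(CN(C)C)c2ccc(C)cc21` — 622000 nM

Both compounds were run in an ADME assay on MT4 cells (Homo sapiens) for cytotoxicity, read by spectrophotometry, with a stated time of 5 days; on this read-out lower numbers stand for higher toxicity in this test and higher numbers for lower toxicity in this test. Compound 1 gives 562000 nM there. Compound 2 gives 622000 nM in this assay, the highest of the two numbers, although the gap to compound 1 is within the scatter, so the two are read as indistinguishable.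

Compound 3 `Cc1ccc2c(c1)/C(=N/NC(=S)NO)C(=O)N2CN(C)C` is not yet measured in this assay. It differs from compound 2 by hydrogen in place of methyl on an oxygen. For the measured compounds named here, no step between measured compounds covers this change, so there is no direct precedent; the only guide is that compound 1, bearing a hydroxyamino group, and compound 2, bearing a methoxyamino group, sit within the scatter of each other in this assay.

For compound 3 the step of a 1.0-fold lower number from compound 2 to compound 3 (0.02 log units; within the scatter) is expected to be small, with no direction beyond the scatter. Compound 3 is estimated at 600000 nM, in the range 300000 nM to 1200000 nM.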

Compound 3, half-maximal cytotoxic concentration: 651000 nM
For compound 3 the middle estimate is 1.1-fold (0.04 log units) below the measured one; low and high end bracket the measured number.
By their numbers in this assay, from the lowest: compounds 1, 2 and 3 (each within the scatter of the next).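

In this assay, for the compounds shown here, compound 2 and compound 3 form the first pair that differs in one place only, and methoxyamino to hydroxyamino gives a 1.0-fold higher number from compound 2 to compound 3 (0.02 log units; within the scatter). On this core, then, hydrogen in place of methyl on an oxygen whose other neighbours are amide-type nitrogen leaves the two compounds indistinguishable in this read-out, something the comparison of compound 1 with compound 2 could not isolate, as those two differ in more than one place. No measurement here offers an explanation for this result.

The compounds shown leave open whether a longer chain on this oxygen, such as ethyl or benzyl, or a plain amino group in place of hydroxyamino, would stay within the same range. They also leave open whether the same change reads alike on the core of compound 1.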